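Disulfide nucleosides: half-life at the assay limit

The source may hold more compounds than are shown below. What is called first, only, known or untested is meant among the compounds shown, and "the series" means these compounds.

Within the data shown here, compound 3 `Cc1cn([C@H]2C[C@H](SSc3ccc([N+](=O)[O-])cc3)[C@@H](CO)O2)c(=O)[nH]c1=O` is one of three compounds measured so far in a physicochemical assay for pharmacokinetics, at pH 7.2; on this read-out higher numbers stand for a longer-lived compound and lower numbers for a shorter-lived compound. Compound 3 gives < 0.0834 h, which is a limit of the assay and not a number. Compound 1 `CSS[C@H]1C[C@H](n2ccc(N)nc2=O)O[C@@H]1CO` likewise gives only a limit, < 0.0834 h. Compound 2 `Cc1cn([C@H]2C[C@H](SSC(Cl)(Cl)Cl)[C@@H](CO)O2)c(=O)[nH]c1=O` also gives a limit, < 0.0834 h. Among the measured compounds shown here, because of the limit of < 0.0834 h in this assay, at which 3 of the 3 values shown sit, no value can yet be placed above the others, and the one single-point change, a step that the two limits leave unreadable from compound 2 to compound 3, cannot be read in size or direction.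

Compound 4 `CCCCSS[C@H]1C[C@H](n2cc(C)c(=O)[nH]c2=O)O[C@@H]1CO` differs from compound 3 by butyl in place of 4-nitrophenyl on a sulfur. For the measured compounds named here, no measured step with a readable size bears on this change; the only comparable exchange on the same sulfur, from compound 2 to compound 3, left both compounds at the limit. On that basis compound 4 is expected to remain at or near the limit, with an expected step that the limit leaves unreadable from compound 3 to compound 4 that would not be readable against it. The estimate for compound 4 is 0.05 h, with a range from 0.015 h to 0.25 h.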

Compound 4, half-life: < 0.0834 h
Compound 4: no number, only a limit (the forecaster's own chance of this, stated with the estimate: 75%); the middle value does not contradict the limit.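

Compound 4 sits at a limit, as do compound 2 and compound 3, so neither the step from compound 3 to compound 4 nor that from compound 2 to compound 4 can be read: the limit of < 0.0834 h in this assay, at which 4 of the 4 values shown sit.

The compounds shown leave open how long any of them lasts in this assay and whether the group on this sulfur affects it.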